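Methoxy for nitro on the aryl ring of compound 3

A few compounds are considered here, and "the series" means these few. Any claim that something is new, unique, unknown or untested is made for them only; others in the source may bear on it.

Three members of the series have been run in a functional assay on SK-MEL-2 cells (Homo sapiens) for cytotoxicity, read by sulforhodamine B assay, with a stated time of 2 days, tested at 100 uM; on this read-out lower numbers stand for less inhibition and higher numbers for more inhibition at the one concentration tested (going by the name of the read-out). Compound 1 `CCCc1n[nH]c2c(=O)n(NC(=O)c3ccncc3)c(-c3cccc(OC)c3)nc12` gives 11.4%. Compound 2 `O=C(Nn1c(-c2cccc([N+](=O)[O-])c2)nc2c(CCc3ccccc3)n[nH]c2c1=O)c1cccnc1` gives 28.5%. Compound 3 `CCCc1n[nH]c2c(=O)n(NC(=O)c3ccccc3)c(-c3cccc([N+](=O)[O-])c3)nc12` gives 22.9%, the second highest of the three numbers; its gap to compound 2 lies within the scatter, while its gap to compound 1 is beyond it, so only compound 3 and compound 1 are separated here. For the measured compounds named here, no two measured compounds differ in a single place, so no step has been computed between them; compound 3 and compound 1 differ both in the aryl substituent and in the carboxamide, and their values alone say that the methoxy-bearing, pyridine-carboxamide compound 1 sits lower.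

Compound 4 `CCCc1n[nH]c2c(=O)n(NC(=O)c3ccccc3)c(-c3cccc(OC)c3)nc12` is the unmeasured member. From compound 3 it differs as follows: methoxy in place of nitro on an aromatic carbon. Going by the values given here, the only methoxy-bearing compound measured, compound 1 at 11.4%, sits low, so a drop is the expected direction for compound 4 in this assay, though a change within the scatter cannot be excluded. The expected step from compound 3 to compound 4 is a number 8.9 percentage points lower from compound 3 to compound 4 (within the scatter), a modest fall. Compound 4 is accordingly estimated at 14%, with a range from 4% to 26%.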

Compound 4, a percentage reported as inhibition, at one concentration (the size of the read-out at that concentration, not a potency): 16.7%
The estimate for compound 4 lay 2.7 percentage points below the measured number, within the range that was stated.
By their numbers in this assay, from the lowest: compounds 1, 4, 3 and 2 (each within the scatter of the next, the first and the last beyond it).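

In this assay, the change from 3-nitrophenyl to 3-methoxyphenyl now has a direct single-place reading on the shared core, a number 6.2 percentage points lower from compound 3 to compound 4 (within the scatter), so this swap on the aromatic carbon does not separate the pair. The carboxamide also gets its first single-place reading, phenyl in place of pyridin-4-yl on a carbonyl carbon, a number 5.3 percentage points higher from compound 1 to compound 4 (within the scatter), and compound 4 thereby joins compound 3 and compound 1 through two steps, neither of which is beyond the scatter on its own. No measurement at hand offers an explanation for either step.

For the compounds shown here, still open is whether an amine, a carboxylic acid or a plain hydrogen on this aromatic carbon would give a step beyond the scatter, since nitro and methoxy are the only groups compared there. Also open, as far as these compounds go, is whether the nitro-to-methoxy step holds on a core carrying the phenylethyl chain of compound 2 rather than propyl, and whether any of these readings at a single concentration would carry over to a potency.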